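The source may report more compounds than this note shows. Statements on the series, on what has been measured and on what is new or still open speak of the compounds shown alone.

Compound 1 `CCn1c(/C=C2/C(=O)Nc3ccccc32)nc2ccccc21`: > 50000 nM
Compound 2 `Cn1c(/C=C2/C(=O)Nc3ccc([N+](=O)[O-])cc32)nc2ccccc21`: "not determined" (no result reported)
Compound 3 `CC(C)n1c(/C=C2/C(=O)Nc3ccc(Cl)cc32)nc2ccccc21`: 32800 nM

Three compounds share one core, and two of them carry a number or a limit in a functional assay on HGC cells (Homo sapiens) for cytotoxicity, read by MTT assay, with a stated time of 48 h; on this read-out higher numbers stand for weaker inhibition and lower numbers for stronger inhibition. For compound 1 the result in this assay is a limit of the assay, > 50000 nM, and not a number; this is the point at which (the limit of > 50000 nM in this assay, at which 1 of the 3 values shown sits). Compound 3 gives 32800 nM in this assay. Compound 2, the nitro-bearing member, stands apart: in this assay its entry is "not determined" (no result reported), so no number places it against the other two, and nothing shows how nitro compares with chloro or with an unsubstituted ring on this core.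

Compound 4 `Cn1c(/C=C2/C(=O)Nc3ccc(F)cc32)nc2ccccc21` is the next member. It differs from compound 2 by fluoro in place of nitro on an aromatic carbon. Within the data shown here, with no value for compound 2, no step can be measured from it, and no step between any two measured compounds is known, so in this assay no direction and no size of change can be expected beyond the scatter; the only anchors are compound 1 at its limit and compound 3 at a weak number. Compound 4 is therefore expected to sit near them, estimated at 40000 nM, with a range from 15000 nM to 100000 nM.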

Compound 4, half-maximal inhibitory concentration: 37800 nM
Estimate against measurement, compound 4: 1.1-fold (0.02 log units) above; the range from low to high includes it.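

In this assay, among these compounds, compound 4 gives 37800 nM, while compound 2 has the entry "not determined" (no result reported), so no step from nitro to fluoro can be read. The compounds shown leave open how any single change on the shared core shifts cytotoxicity. No available evidence bears on the value of compound 4.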